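A few compounds are considered here, and "the series" means these few. Any claim that something is new, unique, unknown or untested is made for them only; others in the source may bear on it.

Measured in an ADME assay on microsomes from liver (Homo sapiens) for pharmacokinetics, read by LC-MS, with a stated time of 60 min, tested at 1 uM; a lower number here means slower removal, a higher number faster removal of the compound:
Compound 1 `O=C(NCc1ccc(S(=O)(=O)c2cncc(C(F)(F)F)c2)cc1)N1Cc2ccncc2C1`: 13 mL/min/kg
Compound 2 `O=C(NCc1ccc(S(=O)(=O)C2CCCCC2)cc1)N1Cc2ccncc2C1`: 16 mL/min/kg

In this assay, compound 2 stands within the scatter of compound 1, so the two cannot be ranked. The next compound, compound 3 `O=C(NCc1ccc(S(=O)(=O)C2CCCOC2)cc1)N1Cc2ccncc2C1`, has not yet been measured. It carries oxan-3-yl in place of cyclohexyl on a sulfonyl sulfur.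

Among the compounds with values here, only one measured step bears on this change, and only indirectly. It is a 1.2-fold higher number from compound 1 to compound 2 (0.09 log units; within the scatter), which stays within the scatter. Within the data shown here, that step concerns the same place on the sulfonyl sulfur, with cyclohexyl in place of 5-(trifluoromethyl)pyridin-3-yl, but no measured pair shows the exchange of cyclohexyl for oxan-3-yl. A change beyond the scatter is therefore not expected, though a small move to a lower number is thought likely. The expected step is a 1.3-fold lower number from compound 2 to compound 3 (0.12 log units; within the scatter). For compound 3 the estimated value is 12 mL/min/kg, with an expected range from 7 mL/min/kg to 20 mL/min/kg.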

Compound 3, clearance: 7 mL/min/kg
Compound 3: the middle estimate sits 1.7-fold (0.23 log units) above what was measured; measured number inside the range.
By their numbers in this assay, from the lowest: compounds 3, 1 and 2 (each within the scatter of the next, the first and the last beyond it).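

In this assay, the exchange of cyclohexyl for oxan-3-yl on a sulfonyl sulfur gives the first step beyond the scatter among these compounds, a 2.3-fold lower number from compound 2 to compound 3 (0.36 log units; beyond the scatter), though a modest one. The ring size and heavy-atom count stay the same, so a single oxygen in place of a ring carbon, which adds a hydrogen-bond acceptor, is enough to produce this difference. Against the 5-(trifluoromethyl)pyridin-3-yl group, however, the result is a 1.9-fold lower number from compound 1 to compound 3 (0.27 log units; within the scatter), so compound 3 cannot be ranked against compound 1.

Nothing available here accounts for the step from cyclohexyl to oxan-3-yl. As far as these compounds go, it also remains open whether the oxygen's place in the ring matters, as oxan-4-yl would show, and whether a ring amine such as piperidin-3-yl would behave in the same way.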